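This account rests on a few compounds, and the source may have more. Where it says the series, first, only, none or still open, it means among the compounds named here.

Working notes on the series. In a functional assay on U-937 cells (Homo sapiens) for antiproliferative activity, read by MTT assay, with a stated time of 24 h (on this read-out higher numbers stand for weaker inhibition and lower numbers for stronger inhibition), compound 1 (`CCCCc1oc2ccccc2c1C(=O)c1ccc(OCC(=O)NC(C)C)cc1`) gives 17500 nM, compound 2 (`CCCCc1oc2ccccc2c1C(=O)c1ccc(OCC(=O)N2CCCC2)cc1`) gives 32500 nM and compound 3 (`CCCCc1oc2ccccc2c1C(=O)c1ccc(OCC(=O)N[C@H](C)c2ccccc2)cc1`) gives 19800 nM. Compound 3 is not separated from either of the others: the data show a 1.1-fold higher number from compound 1 to compound 3 (0.05 log units; within the scatter) and a 1.6-fold lower number from compound 2 to compound 3 (0.22 log units; within the scatter).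

The next structure is compound 4 (`CCCCc1oc2ccccc2c1C(=O)c1ccc(OCCCC(=O)N2CCCCC2)cc1`), with 2-((piperidin-1-yl)carbonyl)ethyl in place of (1-phenylethyl)carbamoyl on a saturated chain carbon bound to an oxygen on an aromatic ring.

The closest measured evidence is the change of amide group, seen in a 1.9-fold higher number from compound 1 to compound 2 (0.27 log units; within the scatter) as well as in the two steps above. For the measured compounds named here, no measured compound carries the entering group, so its effect is untested and the uncertainty is wide. With all three steps small, no step beyond the scatter is expected in this assay. The estimated step is a 1.3-fold higher number from compound 3 to compound 4 (0.10 log units; within the scatter). Compound 4 is expected at 25000 nM, with an estimated range of 10000 nM to 60000 nM.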

Compound 4, half-maximal inhibitory concentration: 16600 nM
The estimate for compound 4 lay 1.5-fold (0.18 log units) above the measured number, and the stated range covers the measured number.
By their numbers in this assay, from the lowest: compounds 4, 1, 3 and 2 (each within the scatter of the next).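

In this assay, the 2-((piperidin-1-yl)carbonyl)ethyl group, on a saturated chain carbon bound to an oxygen on an aromatic ring, stays within the scatter of all three earlier groups: a 1.2-fold lower number from compound 3 to compound 4 (0.08 log units; within the scatter), a 2.0-fold lower number from compound 2 to compound 4 (0.29 log units; within the scatter) and a 1.1-fold lower number from compound 1 to compound 4 (0.02 log units; within the scatter). Compounds 1, 2 and 3 differed only in the amide group, whereas compound 4 also differs in the chain carrying it, and even this wider change gives no step beyond the scatter. No available evidence bears on this result.

The effects of the chain and the amide group remain unseparated, as no compound shown pairs the piperidine amide with the shorter chain. On these data alone, it also remains open whether a carboxylic acid or a primary amine at this place would give a step beyond the scatter.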